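Fluoro in place of nitro on the sulfonyl aryl ring

The compounds below may be only part of what the source reports. "The series", "measured", "known", "first", "only" and "open" are said of these compounds alone.

For the measured compounds named here, in a functional assay on HeLa cells (Homo sapiens) for antiproliferative activity, read by MTT assay, with a stated time of 24 h (on this read-out lower numbers stand for stronger inhibition and higher numbers for weaker inhibition), compound 2 `O=[N+]([O-])c1ccc(S(=O)(=O)n2c(-c3cn(-c4ccccc4)nc3-c3ccc(F)cc3)nc3ccccc32)cc1` gives 1170 nM and stands highest of the two numbers so far, ahead of compound 1 `COc1ccc(S(=O)(=O)n2c(-c3cn(-c4ccccc4)nc3-c3ccc(F)cc3)nc3ccccc32)cc1` at 390 nM on the same read-out. Compound 3 `O=S(=O)(c1ccc(F)cc1)n1c(-c2cn(-c3ccccc3)nc2-c2ccc(F)cc2)nc2ccccc21` carries fluoro in place of nitro on an aromatic carbon, para to a large group (fluoro in place of nitro on an aromatic carbon). Going by the values given here, only one measured step bears on this, the modest 3.0-fold higher number from compound 1 to compound 2 (0.48 log units; beyond the scatter) with nitro in place of methoxy at the same place. Losing nitro is therefore expected to give a step of similar or smaller size toward a lower number (a 2.0-fold lower number from compound 2 to compound 3 (0.29 log units; within the scatter)). In this assay compound 3 is estimated at 600 nM with an expected range (250 nM to 1400 nM).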

Compound 3, half-maximal inhibitory concentration: 2440 nM
For compound 3 the middle estimate is 4.1-fold (0.61 log units) below the measured one; the measured number lies above the stated range.
By their numbers in this assay, from the lowest: compound 1; then compound 2; then compound 3.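

At this position, in this assay, replacing nitro with fluoro gives a 2.1-fold higher number from compound 2 to compound 3 (0.32 log units; beyond the scatter) and so moves the number further in the direction of the earlier change from methoxy to nitro. Fluoro in place of methoxy gives a 6.3-fold higher number from compound 1 to compound 3 (0.80 log units; beyond the scatter) and is the largest of the steps at this position, so the three groups rank from the lowest number as methoxy, nitro, fluoro. Nothing measured here accounts for this order.

On these data alone, whether an amine or a carboxylic acid at this position would give a number lower than that of compound 1 remains open. So does whether a longer chain, such as ethoxy, would keep the number of compound 1.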